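The source may report more compounds than this note shows. Statements on the series, on what has been measured and on what is new or still open speak of the compounds shown alone.

Measured in an ADME assay on the whole organism (Rattus norvegicus, strain Wistar Han) for pharmacokinetics, read by LC-MS, with a stated time of 7 h (on this read-out higher numbers stand for fast clearance and lower numbers for slow clearance), so far:
compound 1 `CNC(=O)c1cc(C(=O)N[C@H]2[C@@H]3COC[C@@H]32)c([C@@H](C)c2ccccc2)o1` gives 55 mL/min/kg
compound 2 `CNC(=O)c1cc(C(=O)N[C@H]2CC[C@H](OC)CC2)n([C@@H](C)c2ccccc2)n1` gives 32 mL/min/kg

Compound 1 stands within the scatter of compound 2, so no order is drawn between the two. Compound 3 `CNC(=O)c1cc(C(=O)N[C@H]2CC[C@H](O)CC2)c([C@@H](C)c2ccccc2)o1` differs from compound 1 in one place, on an amide-type nitrogen, where 4-hydroxycyclohexyl enters: a group of 7 heavy atoms (6 carbon, 1 oxygen; one six-membered non-aromatic ring of carbon only) in place of a group of 6 heavy atoms (5 carbon, 1 oxygen; one three-membered non-aromatic ring of carbon only, one five-membered non-aromatic ring with 1 hetero atom), on an amide-type nitrogen. Going by the values given here, no measured pair shows this change, so no shift beyond the scatter is expected in this assay. The expected move is a small one downward, with the estimated step of a 1.4-fold lower number from compound 1 to compound 3 (0.14 log units; within the scatter) staying within the scatter. The estimate for compound 3 is 40 mL/min/kg, with an expected range from 20 mL/min/kg to 70 mL/min/kg.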

Compound 3, clearance: 30 mL/min/kg
Estimate against measurement, compound 3: 1.3-fold (0.12 log units) above, within the range that was stated.
By their numbers in this assay, from the lowest: compounds 3, 2 and 1 (each within the scatter of the next).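

In this assay, 4-hydroxycyclohexyl in place of the group on the amide-type nitrogen of compound 1 gives a 1.8-fold lower number from compound 1 to compound 3 (0.26 log units; within the scatter), so this first one-place exchange in the series shows no shift beyond the scatter. The amide-type nitrogen therefore carries either group with clearance still inside the scatter. No measurement here bears on what lies behind this step.

Open, from the compounds shown here alone, is how plain cyclohexyl or an aminocyclohexyl would read on the same amide-type nitrogen. Also open, going by these compounds, is whether any group there moves clearance beyond the scatter.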